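The source may hold more compounds than are shown below. What is called first, only, known or untested is meant among the compounds shown, and "the series" means these compounds.

Three compounds have values in a functional assay on HL-60 cells (Homo sapiens) for inhibition, read by MTT assay, with a stated time of 48 h, tested at 10 uM; a higher number here means more inhibition of growth at the concentration tested, a lower number less inhibition of growth. Compound 1 `Cc1cc(=O)c2c(O)cc(OC/C=C/c3ccccc3)c([C@H]3CCN(C)C[C@H]3O)c2o1` gives 21%, and compound 2 `Cc1oc2c([C@H]3CCN(C)C[C@H]3O)c(O)cc(O)c2c(=O)c1C(O)c1cc(F)cc(F)c1` gives 30%. Compound 3 `CN1CC[C@H](c2c(O)cc(O)c3c(=O)cc(/C=C/c4ccccc4)oc23)[C@H](O)C1` gives 91%, the highest of the three and beyond the scatter of both others, with compound 2 the nearest and compound 1 the furthest.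

The unmeasured compound 4 `CN1CC[C@H](c2c(O)cc(O)c3c(=O)cc(/C=C/c4cccc(Cl)c4)oc23)[C@H](O)C1` differs from compound 3 in one place: chloro in place of hydrogen on an aromatic carbon. This is chloro in place of hydrogen on an aromatic carbon, meta to a large group, turning the phenyl into 3-chlorophenyl.

Among the measured compounds shown here, no two measured compounds differ in one place only, so the series offers no direct precedent for this change. The step in this assay is expected to stay within the scatter, with any drift more likely downward, since compound 3 at 91% already stands close to the top of the scale. The estimated change is a number 6 percentage points lower from compound 3 to compound 4 (within the scatter). Compound 4 is expected at 85%, with an estimated range of 62% to 98%.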

Compound 4, percent growth inhibition at one concentration: 35%
The estimate for compound 4 lay 50 percentage points above the measured number, and the stated range ends above it.
By their numbers in this assay, from the lowest: compounds 1, 2 and 4 (each within the scatter of the next, the first and the last beyond it); then compound 3.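

In this assay, the phenyl of the 2-phenylethenyl group proves sensitive to substitution: chloro in place of hydrogen on an aromatic carbon, meta to a large group, gives a number 56 percentage points lower from compound 3 to compound 4 (beyond the scatter). Among the compounds shown here, a single chlorine atom, turning phenyl into 3-chlorophenyl, is enough to remove most of the growth inhibition of compound 3 at 91%, a sensitivity that could not be read from the earlier compounds, none of which differed in one place only. No measurement at hand accounts for this loss.

On these data alone, whether the loss is specific to chloro or follows any group at this place remains open. Methoxy or a dimethylamino group on the same aromatic carbon would help to separate these two readings.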